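Oxadiazole in place of acetamido: an expected cytotoxicity limit

The source may report more compounds than this note shows. Statements on the series, on what has been measured and on what is new or still open speak of the compounds shown alone.

Compound 1 `CC(C)N(Cc1cccc(OCCCCCC(=O)O)c1)C(=O)c1ccc(-c2cccc(OC(F)(F)F)c2)cc1` in an ADME assay on Raji cells (Homo sapiens) for cytotoxicity, read by CellTiter-Glo and resazurin assay, with a stated time of 72 h (on this read-out higher numbers stand for an effect only at larger amounts of compound and lower numbers for an effect already at smaller amounts), gives > 26000 nM, a limit of the assay rather than a number.
Compound 2 `CCOC(=O)CCCCCOc1cccc(CN(C(=O)c2ccc(-c3cccc(NC(C)=O)c3)cc2)C(C)C)c1` in this assay gives > 26000 nM, again a limit of the assay.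

Both measured compounds therefore sit at the same ceiling, and compound 2 stands exactly where compound 1 does, with no number to rank them. Compound 3 `CCOC(=O)CCCCCOc1cccc(CN(C(=O)c2ccc(-c3cccc(-c4nnc(C)o4)c3)cc2)C(C)C)c1` has not been measured. It differs from compound 2 by 5-methyl-1,3,4-oxadiazol-2-yl in place of acetamido on an aromatic carbon; the acetamido group leaves and a five-membered aromatic ring with 3 hetero atoms enters, on the same aromatic carbon of the six-membered ring of carbon only. Among the compounds with values here, no step between measured compounds exists to show what such a change does in this assay. Because (the limit of > 26000 nM in this assay, at which 2 of the 2 values shown sit), the expectation is that compound 3 stays at that same limit, with no shift beyond the scatter. Compound 3 is estimated at 30000 nM, between 12000 nM and 80000 nM, which means an expected step that the limit leaves unreadable from compound 2 to compound 3.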

Compound 3, half-maximal effective concentration: > 26000 nM
Compound 3 gave a limit, no number (the forecaster's own chance of this, stated with the estimate: 80%); the middle value does not contradict the limit.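

Within the data shown here, compound 2 and compound 3 both sit at a limit of this assay, so no step between them can be read. The compounds shown leave open whether 5-methyl-1,3,4-oxadiazol-2-yl in place of acetamido makes any difference, and at what amount any of them would affect these cells.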